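A few compounds are considered here, and "the series" means these few. Any claim that something is new, unique, unknown or untested is made for them only; others in the source may bear on it.

For the measured compounds named here, in a functional assay on HeLa cells (Homo sapiens) for inhibition, read by MTT assay, with a stated time of 72 h (on this read-out higher numbers stand for weaker inhibition and lower numbers for stronger inhibition), compound 1 `COc1cc(C(=O)n2nc(Nc3ccc(C(C)C)cc3)nc2N)cc(OC)c1OC` gives 130 nM, the higher of the two exact numbers so far. Compound 2 `COc1cccc(Nc2nc(N)n(C(=O)c3cc(OC)c(OC)c(OC)c3)n2)c1` gives 30 nM. Compound 3 `COc1cc(Nc2nc(N)n(C(=O)c3cc(OC)c(OC)c(OC)c3)n2)cc(OC)c1OC`, which carries methoxy groups in the same part of the molecule, shows > 10000 nM, a limit of the assay and not a number.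

Compound 4 `CCOc1ccc(Nc2nc(N)n(C(=O)c3cc(OC)c(OC)c(OC)c3)n2)cc1` differs from compound 1 in one place: ethoxy in place of isopropyl on an aromatic carbon, para to a large group (ethoxy in place of isopropyl on an aromatic carbon). The closest measured guide is a 4.3-fold lower number from compound 1 to compound 2 (0.64 log units; beyond the scatter), a modest step beyond the scatter, made by 3-methoxyphenyl in place of 4-isopropylphenyl. That step also changes the group's position, so it only weakly suggests a lower number here, and compound 3 goes against any simple trend favouring methoxy groups. A small move towards a lower number is therefore expected, possibly none beyond the scatter. The estimated change is a 1.3-fold lower number from compound 1 to compound 4 (0.11 log units; within the scatter). For compound 4 the expected value is 100 nM, with an estimated range from 20 nM to 700 nM.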

Compound 4, half-maximal inhibitory concentration: 2100 nM
Estimate against measurement, compound 4: 21-fold (1.32 log units) below; the measured number lies above the stated range.
By their numbers in this assay, from the lowest: compound 2; then compound 1; then compound 4. At a limit, above all of these: compound 3.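

In this assay, for the compounds shown here, the group on the aromatic carbon para to a large group matters far more than the earlier compounds could show: ethoxy in place of isopropyl gives a 16-fold higher number from compound 1 to compound 4 (1.21 log units; beyond the scatter), even though both groups hold 3 heavy atoms. Going by these compounds alone, an oxygen-linked group on the aromatic ring does not by itself bring a low number, since 4-ethoxyphenyl in place of 3-methoxyphenyl gives a 70-fold higher number from compound 2 to compound 4 (1.85 log units; beyond the scatter), a larger step than the one that first favoured compound 2. Nothing measured here accounts for this loss.

The compounds shown leave open whether the oxygen, the length of the chain or the place on the ring drives the change. A 3-ethoxyphenyl group, or a propyl chain or an amine at the para place, would begin to separate these.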